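This account rests on a few compounds, and the source may have more. Where it says the series, first, only, none or still open, it means among the compounds named here.

Compound 3 `CCC(C)(C)Cc1c[nH]c(CCc2ccc(-c3cnccn3)cc2)n1` gives 100 nM in a functional assay on HEK293 cells for agonist activity at Bombesin receptor subtype-3 (Homo sapiens), read by luminescence and calcium flux, with a stated time of 10 min; on this read-out higher numbers stand for an effect only at larger amounts of compound and lower numbers for an effect already at smaller amounts. Among the three numbers shown it stands second highest, with compound 1 `c1ccc(-c2ccc(CCc3nc(CC4CCCC4)c[nH]3)cc2)nc1` at 98 nM and compound 2 `CCC(C)(C)Cc1c[nH]c(CCc2ccc(-c3csnn3)cc2)n1` at 104 nM, both within the scatter of compound 3. Within the data shown here, the only measured step at this position, a 1.0-fold lower number from compound 2 to compound 3 (0.02 log units; within the scatter), swaps one aromatic ring for another and leaves this assay essentially unchanged. Among the measured compounds shown here, compound 4 `CCC(C)(C)Cc1c[nH]c(CCc2ccc(N3CCCCC3)cc2)n1` carries piperidin-1-yl in place of pyrazin-2-yl on an aromatic carbon, an aromatic ring giving way to a non-aromatic one; no measured step of that kind exists here, so the earlier step bears only loosely. A modest upward step is expected, a 2.0-fold higher number from compound 3 to compound 4 (0.30 log units; within the scatter), not clearly beyond the scatter. Compound 4 is estimated at 200 nM, within 60 nM to 700 nM.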

Compound 4, half-maximal effective concentration: 108 nM
Compound 4: the middle estimate sits 1.9-fold (0.27 log units) above what was measured; measured number inside the range.
By their numbers in this assay, from the lowest: compounds 1, 3, 2 and 4 (each within the scatter of the next).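

At this place, on an aromatic carbon para to a large group, a six-membered non-aromatic ring now joins the aromatic rings in this assay without any separation: a 1.1-fold higher number from compound 3 to compound 4 (0.03 log units; within the scatter), and a 1.0-fold higher number from compound 2 to compound 4 (0.02 log units; within the scatter). Among these compounds, the earlier compounds showed only one aromatic ring exchanged for another, so piperidin-1-yl widens the flat range to a non-aromatic ring with one hetero atom. Nothing available explains this flatness. As far as these compounds go, whether a carboxylic acid, a primary amine or a longer alkyl chain on the same carbon would move the number beyond the scatter stays open.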